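Adding an Ethylsulfanyl Group Beside a Retained Nitrile

The compounds below may be only part of what the source reports. "The series", "measured", "known", "first", "only" and "open" are said of these compounds alone.

Among the compounds with values here, compound 1 `Cc1ccc2ccc(-c3cccc(C#N)c3)cc2n1` is the only member of this small set with a true number: in a functional assay on CHO cells for inhibition of metabotropic glutamate receptor 5 (Rattus norvegicus), read by FLIPR and calcium flux (on this read-out lower numbers stand for stronger inhibition and higher numbers for weaker inhibition), compound 1 gives 7.7 nM. Compound 2 `Cc1ccc2ccc(-c3cccc(OC(F)(F)F)c3)cc2n1` reaches only a limit of this assay, at > 10000 nM. Compound 3 `Cc1ccc2ccc(-c3cccc(C(F)(F)F)c3)cc2n1` likewise sits at a limit, at > 10000 nM. Two of the three values therefore lie at the limit of > 10000 nM in this assay, at which 2 of the 3 values shown sit, and compound 1 stands alone below it.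

The new compound 4 `CCSc1cc(C#N)cc(-c2ccc3ccc(C)nc3c2)c1` differs from compound 1 in a single place: ethylsulfanyl in place of hydrogen on an aromatic carbon. The cyano group of compound 1 is kept.

The steps measured so far all concern that cyano group. Swapping it out gives an at least 1200-fold higher number from compound 1 to compound 2 (3.11 log units; beyond the scatter) and an at least 1200-fold higher number from compound 1 to compound 3 (3.11 log units; beyond the scatter), both large. The step between compound 2 and compound 3 is a step that the two limits leave unreadable from compound 2 to compound 3. Within the data shown here, none of these steps touches the position that changes in compound 4, and no measured pair shows an ethylsulfanyl group entering at a carbon that keeps a cyano group. Since the cyano group survives in compound 4, the large losses seen on its removal are not expected to repeat; a step of about a 1.9-fold higher number from compound 1 to compound 4 (0.29 log units; within the scatter) is expected, close to the scatter. The value of compound 4 in this assay is estimated at 15 nM, in the range 4 nM to 60 nM.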

Compound 4, half-maximal inhibitory concentration: 72 nM
Estimate against measurement, compound 4: 4.8-fold (0.68 log units) below; measured number outside the range, above it.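

The earlier compounds shown here changed only the cyano group and said nothing about this position on the ring, meta to a cyano group and meta to a large group. Compound 4 shows that the position responds to substitution: in this assay, ethylsulfanyl in place of hydrogen gives a 9.4-fold higher number from compound 1 to compound 4 (0.97 log units; beyond the scatter), so the change carries a real cost even with the cyano group kept, yet that cost is much smaller than the large steps seen when the cyano group of compound 1 is replaced. Nothing measured here accounts for the size of this step.

With one group at this position, the compounds shown cannot tell whether the step follows from the sulfur atom, from the ethyl chain or from the presence of any group other than hydrogen; a methyl group, a methoxy group, a fluorine atom or a longer chain such as propylsulfanyl at the same carbon would begin to separate these. On these data alone, it also remains open whether ethylsulfanyl would have any comparable effect in a compound carrying trifluoromethyl or trifluoromethoxy in place of the cyano group.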